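The compounds below may be only part of what the source reports. "The series", "measured", "known", "first", "only" and "open" are said of these compounds alone.

Compound 1 `CCCCCCCCSC[C@H](NC(C)=O)C(=O)CCl` gives 4100 nM in a functional assay on MOLT-3 cells (Homo sapiens); a lower number here means a stronger inhibitor, a higher number a weaker inhibitor. Among the compounds with values here, compound 2 `CCCCCCCCCCCCCCSC[C@H](NC(C)=O)C(=O)CCl` gives 8800 nM in this assay, the highest of the two numbers measured so far. Within the data shown here, the one step between them, a 2.1-fold higher number from compound 1 to compound 2 (0.33 log units; beyond the scatter), is the only measured step that bears on the next change. Compound 3 `CCCCCCCCCCCCCCCCCCCCSC[C@H](NC(C)=O)C(=O)CCl` carries the difference (hexyl in place of hydrogen on a saturated chain carbon, ten or more bonds along the chain from a sulfur). Since the same kind of extension weakened inhibition modestly before, a further weakening of similar size is expected, and a 2.0-fold higher number from compound 2 to compound 3 (0.31 log units; beyond the scatter) is the estimated step. Compound 3 is therefore expected to give about 18000 nM, with a likely range from 8000 nM to 45000 nM.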

Compound 3, half-maximal inhibitory concentration: > 100000 nM
Compound 3: no number, only a limit (the forecaster's own chance of this, stated with the estimate: 15%); middle value at least 5.5-fold (0.74 log units) from the limit.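

The same hexyl addition that gave a modest step, a 2.1-fold higher number from compound 1 to compound 2 (0.33 log units; beyond the scatter), now gives a large one, an at least 11-fold higher number from compound 2 to compound 3 (1.05 log units; beyond the scatter). Lengthening this chain therefore does not weaken inhibition by an even amount with each addition in this assay. For compound 3 the reading is a limit of the assay, not a number: the limit of > 100000 nM in this assay, at which 1 of the 3 values shown sits.

The compounds shown leave open where between compound 2 and compound 3 the large loss sets in. They also leave open whether a shorter butyl chain, or a chain carrying an amine, would give stronger inhibition.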